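The source may hold more compounds than are shown below. What is called first, only, known or untested is meant among the compounds shown, and "the series" means these compounds.

Compound 1 `O=c1ccc(CCOCc2ccccc2)nn1Cc1ccccc1` was examined in a functional assay on aorta (Rattus norvegicus) (on this read-out lower numbers stand for stronger inhibition and higher numbers for weaker inhibition), where compound 1 gives 32300 nM. Compound 2 `Cn1nc(CCOCc2ccccc2)ccc1=O` carries hydrogen in place of phenyl on a saturated chain carbon bound to an aromatic nitrogen relative to compound 1. In this assay compound 2 reaches only a limit of the assay, > 100000 nM. The step of an at least 3.0-fold higher number from compound 1 to compound 2 (0.49 log units; beyond the scatter) therefore rests on (the limit of > 100000 nM in this assay, at which 1 of the 3 values shown sits). Compound 3 `O=c1ccc(COCc2ccccc2)nn1Cc1ccccc1` differs from compound 1 by a change in the core that is not broken down here; in this assay compound 3 gives 35300 nM, a value within the scatter of compound 1. Compound 4 `Cn1nc(COCc2ccccc2)ccc1=O` is not yet measured; it carries hydrogen in place of phenyl on a saturated chain carbon bound to an aromatic nitrogen relative to compound 3, the same change at the same place as seen between compound 1 and compound 2. Given the earlier step of an at least 3.0-fold higher number from compound 1 to compound 2 (0.49 log units; beyond the scatter), a comparable weakening is expected, a 3.1-fold higher number from compound 3 to compound 4 (0.49 log units; beyond the scatter). Compound 4 is thus expected to give roughly 110000 nM in this assay, quite possibly reported only as a limit, with a range from 60000 nM to 300000 nM.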

Compound 4, half-maximal inhibitory concentration: > 100000 nM
Compound 4: a limit, no number; the forecaster's own chance of this, stated with the estimate: 60%; the middle value is on the limit's open side.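

In this assay compound 4 reaches only a limit of the assay, > 100000 nM and not a number. The change from benzyl to methyl gives an at least 2.8-fold higher number from compound 3 to compound 4 (0.45 log units; beyond the scatter) on this core, so it weakens inhibition in the same direction on both cores shown: the same change on two cores in this assay, an at least 3.0-fold higher number (0.49 log units; beyond the scatter) from compound 1 to compound 2 and an at least 2.8-fold higher number (0.45 log units; beyond the scatter) from compound 3 to compound 4; the limit leaves it open whether they differ. As far as these compounds go, the true size of the step on either core remains unknown because the methyl compounds rest on a limit: the limit of > 100000 nM in this assay, at which 2 of the 4 values shown sit.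

The compounds shown leave open how an ethyl group or a longer chain would behave in place of benzyl. They also leave open whether a benzyl group carrying an amine or a carboxylic acid on its phenyl ring would keep the inhibition seen with benzyl.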